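Removing the Side Chain from Compound 1

This account rests on a few compounds, and the source may have more. Where it says the series, first, only, none or still open, it means among the compounds named here.

Compound 1 `C=CC(C)(C)c1[nH]c2ccc(C[C@H](OC(C)=O)C(C)(C)O)cc2c1/C=C1\NC(=O)[C@H](C)NC1=O` was examined in an ADME assay on MDCK cells (Canis lupus familiaris) for cytotoxicity, read by CellTiter-Glo, with a stated time of 40 h; on this read-out lower numbers stand for higher toxicity in this test and higher numbers for lower toxicity in this test. In this assay compound 1 gives only a limit of > 200000 nM. Two related compounds stand at the same place. Compound 2 `C=CC(C)(C)c1[nH]c2ccc(C[C@H](O)C(C)(C)OC)cc2c1/C=c1\[nH]c(=O)c(=C)[nH]c1=O` gives a limit of > 200000 nM in this assay. Compound 3 `C=CC(C)(C)c1[nH]c2ccc(C[C@H](OC(C)=O)C(C)(C)O)cc2c1C[C@@H]1NC(=O)[C@H](C)NC1=O` likewise gives a limit of > 200000 nM in this assay. Going by the values given here, the only step between measured compounds that differ in a single place, a step that the two limits leave unreadable from compound 1 to compound 3, therefore cannot be read, since both of its ends are limits; all that the measured set shows is the limit of > 200000 nM in this assay, at which 3 of the 3 values shown sit.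

Compound 4 `C=CC(C)(C)c1[nH]c2ccccc2c1/C=C1\NC(=O)[C@H](C)NC1=O` differs from compound 1 in one place: hydrogen in place of 2-acetoxy-3-hydroxy-3-methylbutyl on an aromatic carbon. Among the compounds with values here, no measured step bears directly on this change, as none of the measured pairs removes this side chain, and the one step that exists is unreadable. With every measured compound sitting at the limit, compound 4 is expected to remain there as well. For compound 4 the estimate is 200000 nM, within a range of 100000 nM to 400000 nM. The step of a number no higher from compound 1 to compound 4 (the limit leaves the size open) is accordingly expected to be none beyond the scatter, although a result at the limit would once more leave its size unreadable.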

Compound 4, half-maximal cytotoxic concentration: > 200000 nM
Compound 4 was reported as a limit; the forecaster's own chance of this, stated with the estimate: 85%; the middle value lies on the limit itself.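

In this assay compound 4 gives > 200000 nM, which is a limit. Going by these compounds alone, compound 1 also stands at a limit, so no step between compound 1 and compound 4 can be read. The compounds shown leave open how far each lies from that limit and whether any change to the shared core would give a readable value, for the measured set shows only this: the limit of > 200000 nM in this assay, at which 4 of the 4 values shown sit.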